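A methyl added to a weakly cytotoxic compound

The compounds below may be only part of what the source reports. "The series", "measured", "known", "first", "only" and "open" are said of these compounds alone.

- compound 1 `Cc1cn(-c2csc(Nc3ccc(Br)cc3)n2)c(C)n1` gives 45000 nM in a functional assay on RKO cells (Homo sapiens) for cytotoxicity, read by resazurin assay, with a stated time of 72 h; on this read-out lower numbers stand for stronger inhibition and higher numbers for weaker inhibition
- compound 2 `Cc1ccc(Nc2nc(-n3ccnc3C)cs2)cc1` gives > 100000 nM in this assay

For compound 2 the value > 100000 nM is a limit of the assay and not a number. From the compounds shown here alone, compound 2 thus stands at the limit of > 100000 nM in this assay, at which 1 of the 2 values shown sits, and its true strength is unknown.

Compound 3 `Cc1ccc(Nc2nc(-n3cc(C)nc3C)cs2)cc1` comes from compound 2 through one change methyl in place of hydrogen on an aromatic carbon with methyl in place of hydrogen on an aromatic carbon of a five-membered aromatic ring with 2 nitrogen. Among the measured compounds shown here, no measured pair shows what this change does alone. For the measured compounds named here, the only exact number here belongs to compound 1 at 45000 nM in this assay and so a modest move towards a lower number is expected. Even so, compound 3 may well stay at the limit.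

The expected move is an at least 1.5-fold lower number from compound 2 to compound 3 (0.18 log units; that floor lies within the scatter) as estimated here. For compound 3 the estimated value is 65000 nM with an expected range from 30000 nM to 100000 nM in this estimate.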

Compound 3, half-maximal inhibitory concentration: > 100000 nM
Compound 3 was reported as a limit (the forecaster's own chance of this, stated with the estimate: 35%); middle value at least 1.5-fold (0.18 log units) away from the limit.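

In this assay compound 3 is reported as > 100000 nM, which is a limit of the assay and not a number. The added methyl on the aromatic carbon of the five-membered ring does not bring compound 3 down to a readable number, and its step cannot be read because compound 2 and compound 3 both sit at the limit: the limit of > 100000 nM in this assay, at which 2 of the 3 values shown sit.

Methyl in place of bromo on an aromatic carbon gives an at least 2.2-fold higher number from compound 1 to compound 3 (0.34 log units; beyond the scatter), so with both methyl groups on the five-membered ring present, compound 1 alone keeps an exact number.

From the compounds shown here alone, whether the added methyl changes strength at all remains open. Also open, going by these compounds, is how an amine at that same aromatic carbon, or a chloro group in place of the bromo, would read in this assay.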